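Methyl on the amide nitrogen of a fluoroindole butanamide

The source may hold more compounds than are shown below. What is called first, only, known or untested is meant among the compounds shown, and "the series" means these compounds.

The two measured compounds share the core of compound 1 `NCC(N)CCc1c[nH]c2ccc(F)cc12`, which in an assay on isolated protein (urine) for inhibition of Myeloperoxidase (Homo sapiens), with a stated time of 5 min (a lower number here means a stronger inhibitor, a higher number a weaker inhibitor), gives 60 nM. Compound 2 `NC(=O)CCCc1c[nH]c2ccc(F)cc12` carries a carbamoylmethyl group where compound 1 carries 1,2-diaminoethyl, and in this assay compound 2 gives 18 nM; the step of a 3.3-fold lower number from compound 1 to compound 2 (0.52 log units; beyond the scatter). Compound 2 therefore stands at the lowest of the two numbers, with compound 1 the nearest neighbour at a higher number beyond the scatter.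

Compound 3 `CNC(=O)CCCc1c[nH]c2ccc(F)cc12` differs from compound 2 by methyl in place of hydrogen on an amide-type nitrogen. No measured step bears on this change: the only step shown, from compound 1 to compound 2, replaces a whole side chain and says nothing about substitution on the amide nitrogen itself. With no guidance from the data, a step close to or only a little beyond the scatter is expected, most likely toward a higher number, as a 1.7-fold higher number from compound 2 to compound 3 (0.22 log units; within the scatter).

For compound 3 in this assay, a value of 30 nM is estimated, in a range from 10 nM to 90 nM.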

Compound 3, half-maximal inhibitory concentration: 40 nM
Compound 3: the middle estimate sits 1.3-fold (0.12 log units) below what was measured; the range from low to high includes it.
By their numbers in this assay, from the lowest: compound 2; then compounds 3 and 1 (each within the scatter of the next).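

In this assay, the amide-type nitrogen turns out not to be indifferent to substitution, which the earlier pair could not show: putting methyl in place of the amide hydrogen gives a 2.2-fold higher number from compound 2 to compound 3 (0.35 log units; beyond the scatter), a modest change from only one added carbon. The edge that compound 2 held over compound 1 does not survive this change, since a 1.5-fold lower number from compound 1 to compound 3 (0.18 log units; within the scatter), so the (methylcarbamoyl)methyl and 1,2-diaminoethyl groups cannot be told apart in this measurement, whereas the carbamoylmethyl group of compound 2 stood clear of compound 1. No supporting data bear on why the methyl has this effect.

Whether the number keeps climbing with more carbon on that nitrogen, as with an ethyl group or a second methyl, remains open, as a single methyl is the only substituent shown there. Also open, as far as these compounds go, is how a carboxylic acid in place of the amide, or a longer chain carrying the same primary amide as compound 2, would compare with compound 2 at 18 nM, and whether methyl would have the same effect there.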